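Series notes: hydrogen for fluoro, compound 3

The source may report more compounds than this note shows. Statements on the series, on what has been measured and on what is new or still open speak of the compounds shown alone.

Measured so far:
compound 1 `Cc1c(C(=O)Nc2ccc(Oc3ccnc4[nH]ccc34)c(F)c2)nnn1-c1ccccc1`: 2340 nM
compound 2 `Cc1c(C(=O)Nc2ccc(Oc3ccnc4[nH]ccc34)c(F)c2)nnn1-c1ccc(F)cc1`: 4350 nM

In a functional assay on PC-3 cells (Homo sapiens) for cytotoxicity, read by MTT assay, with a stated time of 72 h (on this read-out lower numbers stand for stronger inhibition and higher numbers for weaker inhibition), compound 1 gives 2340 nM, and compound 2 gives 4350 nM; the two lie within the scatter of each other. Among the measured compounds shown here, the single measured step, a 1.9-fold higher number from compound 1 to compound 2 (0.27 log units; within the scatter), sits on a different ring and does not bear on the change to compound 3 `Cc1c(C(=O)Nc2ccc(Oc3ccnc4[nH]ccc34)cc2)nnn1-c1ccccc1`, which is hydrogen in place of fluoro on an aromatic carbon. For the measured compounds named here, no measured pair tests this position. With nothing pointing either way, the step is expected to stay within the scatter, a 1.1-fold higher number from compound 1 to compound 3 (0.05 log units; within the scatter). Compound 3 is estimated at 2600 nM, range 1000 nM to 7000 nM.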

Compound 3, half-maximal inhibitory concentration: 7260 nM
For compound 3 the middle estimate is 2.8-fold (0.45 log units) below the measured one, and the stated range ends below it.
By their numbers in this assay, from the lowest: compounds 1, 2 and 3 (each within the scatter of the next, the first and the last beyond it).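

In this assay, hydrogen in place of fluoro on the aromatic carbon ortho to a large group gives a 3.1-fold higher number from compound 1 to compound 3 (0.49 log units; beyond the scatter). Among the compounds shown here, this is the first single change to pass beyond the scatter, so this position responds to the change, if modestly, while the step on the other ring, a 1.9-fold higher number from compound 1 to compound 2 (0.27 log units; within the scatter), does not. No available evidence accounts for this step.

Going by these compounds, whether chloro, methoxy or an amine on this carbon would track fluoro or hydrogen stays open. So does whether the step holds with fluoro also present on the other ring.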